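Compound 3: 4-methoxyphenyl in place of 3-bromophenyl

This account rests on a few compounds, and the source may have more. Where it says the series, first, only, none or still open, it means among the compounds named here.

In a functional assay on MDA-MB-231 cells (Homo sapiens) for antiproliferative activity, read by MTT assay, with a stated time of 72 h (on this read-out lower numbers stand for stronger inhibition and higher numbers for weaker inhibition), compound 1 `NC1=NC2(CCSCC2)N(OCCCOc2ccccc2Br)C(N)=N1` gives 10 nM and compound 2 `NC1=NC2(CCSCC2)N(OCCCOc2cccc(Br)c2)C(N)=N1` gives 60 nM, the higher of the two numbers. Compound 3 `COc1ccc(OCCCON2C(N)=NC(N)=NC23CCSCC3)cc1` carries 4-methoxyphenyl in place of 3-bromophenyl on an oxygen on a saturated carbon. Among the measured compounds shown here, one measured step bears on this, a 6.0-fold higher number from compound 1 to compound 2 (0.78 log units; beyond the scatter), a modest one between two bromophenyl groups. For the measured compounds named here, no methoxy compound has been measured, so that step gives no direction. The expected step is a 1.3-fold higher number from compound 2 to compound 3 (0.12 log units; within the scatter), which would stay within the scatter. For compound 3 the estimated value is 80 nM, with an expected range of 20 nM to 300 nM.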

Compound 3, half-maximal inhibitory concentration: 350 nM
The estimate for compound 3 lay 4.4-fold (0.64 log units) below the measured number; measured number above the stated range.
By their numbers in this assay, from the lowest: compound 1; then compound 2; then compound 3.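

The aryl group on this chain carries more of the activity than the two bromophenyl compounds could show: 4-methoxyphenyl in place of 3-bromophenyl gives a 5.8-fold higher number from compound 2 to compound 3 (0.77 log units; beyond the scatter) and, in place of 2-bromophenyl, a 35-fold higher number from compound 1 to compound 3 (1.54 log units; beyond the scatter). Compound 3 is thus the weakest of the three, with both steps beyond the scatter. No measurement shown here explains this loss.

The compounds shown do not separate the methoxy group from its place on the ring. On these data alone, how an amine or a carboxylic acid on the phenyl ring, or a longer chain, would read also remains open.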